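This account rests on a few compounds, and the source may have more. Where it says the series, first, only, none or still open, it means among the compounds named here.

Working notes on the series. For the measured compounds named here, in a functional assay on the whole organism (strain Sprague-Dawley) for inhibition, with Rattus norvegicus as the target, with a stated time of 10 min (on this read-out higher numbers stand for an effect only at larger amounts of compound and lower numbers for an effect already at smaller amounts), compound 1 (`O=C(O)c1cnc(-c2ccccc2)[nH]c1=O`) gives 50 mg/kg, the only true number so far. Compound 2 (`O=C(O)c1cnc(-c2ccc(C(F)(F)F)cc2)[nH]c1=O`) gives > 5 mg/kg, which is a limit and not a number. The series as it stands therefore holds (the limit of > 5 mg/kg in this assay, at which 1 of the 2 values shown sits).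

Compound 3 (`COc1ccc(-c2ncc(C(=O)O)c(=O)[nH]2)cc1`) has methoxy in place of trifluoromethyl on an aromatic carbon, para to a large group: methoxy in place of trifluoromethyl on an aromatic carbon. Going by the values given here, the one measured step that bears on this change is a step that the limit leaves unreadable from compound 1 to compound 2, where trifluoromethyl replaces hydrogen at an aromatic carbon. That step has no readable size, so it gives neither a magnitude nor a direction to carry over to methoxy. Among the compounds with values here, no measured step involves methoxy. The expectation in this assay therefore rests mainly on compound 1 at 50 mg/kg, with a wide margin on both sides. The expected change is a step that the limit leaves unreadable from compound 2 to compound 3, an estimate with no firm direction. For compound 3 the expected value is 20 mg/kg, with an estimated range of 4 mg/kg to 90 mg/kg.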

Compound 3, dose for 50% inhibition: > 5 mg/kg
Compound 3: a limit, no number (the forecaster's own chance of this, stated with the estimate: 30%); the middle value lies beyond the limit too.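

In this assay compound 3 gives only a limit and not a number, so no step from compound 1 or compound 2 to compound 3 can be read: the limit of > 5 mg/kg in this assay, at which 2 of the 3 values shown sit.

The compounds shown leave open whether trifluoromethyl or methoxy in place of hydrogen on the core of compound 1 shifts the read-out at all, and in which direction.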